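Removing the aryl ester: what happens at the hydroxyl

This account rests on a few compounds, and the source may have more. Where it says the series, first, only, none or still open, it means among the compounds named here.

Measured compounds:
- compound 1, `O=C(OC1(C(=O)Nc2ccc([N+](=O)[O-])cc2)CCCCC1)c1ccc(Br)cc1`: 236 nM
- compound 2, `O=C(OC1(C(=O)Nc2ccc([N+](=O)[O-])cc2)CCCCC1)c1ccc([N+](=O)[O-])cc1`: 7.7 nM
- compound 3, `CCOC(=O)c1ccccc1C(=O)OC1(C(=O)Nc2ccc([N+](=O)[O-])cc2)CCCCC1`: 488 nM

In a functional assay on NFS-60 cells (Mus musculus) for inhibition, read by MTT assay, with a stated time of 72 h (on this read-out lower numbers stand for stronger inhibition and higher numbers for weaker inhibition), compound 1 stands second highest of the three numbers. Its nearest neighbour is compound 3, whose number is higher; the furthest is compound 2, reached by a 31-fold lower number from compound 1 to compound 2 (1.49 log units; beyond the scatter), a step beyond the scatter. All three share a core in which an ester hangs from the oxygen of a saturated ring carbon.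

Compound 4, `O=C(Nc1ccc([N+](=O)[O-])cc1)C1(O)CCCCC1`, is not yet measured. It differs from compound 1 in that (hydrogen in place of (4-bromophenyl)carbonyl on an oxygen on a saturated carbon). The whole ester is gone and a free hydroxyl remains.

For the measured compounds named here, no measured step removes the ester, so none bears on this change directly. What the numbers do show is that the ester part matters: swapping one group on its aryl ring gives a 31-fold lower number from compound 1 to compound 2 (1.49 log units; beyond the scatter), and a different aryl ester in compound 3 gives a higher number than compound 1. Deleting the group altogether is therefore expected to move the number well beyond the scatter, most likely upward, though the size is uncertain.

The step from compound 1 to compound 4 is estimated as a 13-fold higher number from compound 1 to compound 4 (1.10 log units; beyond the scatter). Compound 4 is expected to give about 3000 nM, within a range from 500 nM to 20000 nM.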

Compound 4, half-maximal inhibitory concentration: 716 nM
Estimate against measurement, compound 4: 4.2-fold (0.62 log units) above; the measured number falls inside the stated range.
By their numbers in this assay, from the lowest: compound 2; then compound 1; then compounds 3 and 4 (each within the scatter of the next).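

In this assay, removing the whole (4-bromophenyl)carbonyl group to leave a free hydroxyl gives a 3.0-fold higher number from compound 1 to compound 4 (0.48 log units; beyond the scatter), so the shared core still gives a measurable number without any ester. This modest step is smaller than the large one made by changing a single group on the aryl ring, a 31-fold lower number from compound 1 to compound 2 (1.49 log units; beyond the scatter), so among these compounds, the group on the ring moves the number further than removing the ester of compound 1 does. Compound 3 and compound 4 lie within the scatter of each other, so the ester of compound 3 shows no gain over the free hydroxyl.

No measurement shown here explains why the number shifts at this position. As far as these compounds go, it remains open whether a methyl ether, an acetyl ester or an amine in place of the hydroxyl would give a number closer to that of compound 2 or to that of compound 4.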